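Methylating the Amide Nitrogen in a Series of Anilides

The source may hold more compounds than are shown below. What is called first, only, known or untested is meant among the compounds shown, and "the series" means these compounds.

Of the compounds shown here, three built on a shared core have been tested in an assay on isolated protein (Mus musculus) for inhibition of IL15-IL15 receptor (Homo sapiens), read by resazurin assay, with stated times of 30 min and 2.5 days; a higher number here means a weaker inhibitor, a lower number a stronger inhibitor. Compound 1 `Cn1c(Cc2nn(C)c(=O)c3ccccc23)nnc1SCCCCCCCC(=O)Nc1ccc(Cl)cc1Cl` gives 1900 nM. Compound 2 `Cn1c(Cc2nn(C)c(=O)c3ccccc23)nnc1SCCCCCCCCCCC(=O)Nc1ccc(Cl)cc1Cl` gives 3300 nM, and compound 3 `Cn1c(Cc2nn(C)c(=O)c3ccccc23)nnc1S(=O)(=O)CCCCCCCC(=O)Nc1ccc(Br)cc1Br` gives 1400 nM. All three numbers sit within the usual scatter of one another, so none of them can be called stronger or weaker than the rest. Compound 4 `CN(C(=O)CCCCCCCSc1nnc(Cc2nn(C)c(=O)c3ccccc23)n1C)c1ccc(Cl)cc1Cl` has not yet been measured. It differs from compound 1 in a single place: methyl in place of hydrogen on an amide-type nitrogen. Among the compounds with values here, no measured pair in this set shows the same change, so its effect is open. The expected step is a 1.3-fold higher number from compound 1 to compound 4 (0.12 log units; within the scatter), which would stay within the scatter. Compound 4 is therefore estimated to give 2500 nM in this assay, with a likely range from 900 nM to 7000 nM.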

Compound 4, half-maximal inhibitory concentration: 11900 nM
Compound 4: middle estimate off by 4.8-fold (0.68 log units), on the low side, outside the stated range (above it).
By their numbers in this assay, from the lowest: compounds 3, 1 and 2 (each within the scatter of the next, the first and the last beyond it); then compound 4.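

In this assay, within the data shown here, the earlier compounds gave no pair that isolated any single change, and their numbers stayed within the scatter of their neighbours. Putting methyl in place of the amide hydrogen gives a 6.3-fold higher number from compound 1 to compound 4 (0.80 log units; beyond the scatter), so this nitrogen is a place where one added carbon makes the inhibitor measurably weaker. Nothing available here explains the loss. From the compounds shown here alone, whether ethyl on this nitrogen would weaken inhibition further remains open. So does whether methyl would produce a similar step on the longer chain of compound 2.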